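Dimethylamino in place of (tert-butyl)amino on a carbonyl carbon

The compounds below may be only part of what the source reports. "The series", "measured", "known", "first", "only" and "open" are said of these compounds alone.

Measured in a physicochemical assay for solubility; on this read-out higher numbers stand for higher solubility and lower numbers for lower solubility:
compound 1 `CC(=O)N1CCC[C@H]1C(=O)N1CCC(NS(=O)(=O)c2cc(S(=O)(=O)c3ccccc3)ccc2C(F)(F)F)CC1`: 12500 nM
compound 2 `CN(C)CC(=O)N1CCC[C@H]1C(=O)N1CCC(NS(=O)(=O)c2cc(S(=O)(=O)c3ccccc3)ccc2C(F)(F)F)CC1`: 100000 nM
compound 3 `CC(C)(C)NC(=O)N1CCC[C@H]1C(=O)N1CCC(NS(=O)(=O)c2cc(S(=O)(=O)c3ccccc3)ccc2C(F)(F)F)CC1`: 50000 nM

In this assay compound 3 gives 50000 nM. That places it within the scatter of compound 2, as the measured 2.0-fold lower number from compound 2 to compound 3 (0.30 log units; within the scatter) shows, and clear of compound 1, as a 4.0-fold higher number from compound 1 to compound 3 (0.60 log units; beyond the scatter) shows.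

The next compound is compound 4 `CN(C)C(=O)N1CCC[C@H]1C(=O)N1CCC(NS(=O)(=O)c2cc(S(=O)(=O)c3ccccc3)ccc2C(F)(F)F)CC1`. It carries dimethylamino in place of (tert-butyl)amino on a carbonyl carbon, and the rest of the structure stays the same. Among the compounds with values here, no measured step makes this exchange directly, so the evidence is indirect.

Putting (tert-butyl)amino in place of methyl on that carbonyl carbon gave a 4.0-fold higher number from compound 1 to compound 3 (0.60 log units; beyond the scatter). Dimethylamino in place of hydrogen on a saturated chain carbon bound to a carbonyl carbon gave an 8.0-fold higher number from compound 1 to compound 2 (0.90 log units; beyond the scatter). Both changes raised the number by a modest amount, and the two resulting compounds remain within the scatter of each other. Compound 4 is therefore expected to stay near compound 3 rather than fall back towards compound 1 at 12500 nM, although three compounds make thin support.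

The expected change is a 1.3-fold lower number from compound 3 to compound 4 (0.10 log units; within the scatter), which would not go beyond the scatter. For compound 4 the estimated value is 40000 nM, with an expected range of 15000 nM to 100000 nM.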

Compound 4, solubility: 100000 nM
Compound 4: the middle estimate sits 2.5-fold (0.40 log units) below what was measured; measured number inside the range.
By their numbers in this assay, from the lowest: compound 1; then compounds 3, 2 and 4 (each within the scatter of the next).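

In this assay, the exchange on this carbonyl carbon, whose other neighbour is an amide-type nitrogen in a ring, does not separate dimethylamino from (tert-butyl)amino (a 2.0-fold higher number from compound 3 to compound 4 (0.30 log units; within the scatter)), although (tert-butyl)amino carries a hydrogen-bond donor and dimethylamino carries none. Dimethylamino also reads the same as (dimethylamino)methyl on that carbon (no change at the digits printed from compound 2 to compound 4 (within the scatter)), so among compounds 2, 3 and 4 the data show no separation, while dimethylamino in place of methyl stands clear of the scatter (an 8.0-fold higher number from compound 1 to compound 4 (0.90 log units; beyond the scatter)), which makes compound 1 the only one of the four set apart from the others. Nothing among the available data gives a measured property that would account for these readings.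

What the compounds shown leave open is whether other groups on this carbonyl carbon, such as a methoxy group, a morpholine ring or a longer chain ending in an amine, would also stand clear of compound 1. On these data alone, it is equally open whether a carboxylic acid at this place would follow the same pattern as the three groups seen so far.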